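Three benzyl variants at the limit; a 2-nitrophenyl analogue

A few compounds are considered here, and "the series" means these few. Any claim that something is new, unique, unknown or untested is made for them only; others in the source may bear on it.

Compound 1, `CCOC(=O)c1cnc(N2CCN(Cc3ccccc3C#N)CC2)nc1Oc1c(C)cc(-c2ccc(C#N)cc2)cc1C`, in an ADME assay on MT4 cells (Homo sapiens) for cytotoxicity, read by MTT assay, with a stated time of 4 days (a higher number here means that more compound is tolerated, a lower number that less compound is tolerated), gives > 125000 nM, a limit of the assay.
Compound 2, `CCOC(=O)c1cnc(N2CCN(Cc3ccc(C(F)(F)F)cc3)CC2)nc1Oc1c(C)cc(-c2ccc(C#N)cc2)cc1C`, in this assay gives > 125000 nM, again a limit.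
Compound 3, `CCOC(=O)c1cnc(N2CCN(Cc3cccc(Br)c3)CC2)nc1Oc1c(C)cc(-c2ccc(C#N)cc2)cc1C`, in this assay gives > 125000 nM, again a limit.

Compound 2 therefore stands only at a limit, with no number of its own; the two other values shown beside it are limits too. The steps that touch compound 2, a step that the two limits leave unreadable from compound 1 to compound 2 and a step that the two limits leave unreadable from compound 2 to compound 3, are unreadable for the same reason, and so is a step that the two limits leave unreadable from compound 1 to compound 3. What the three measurements share is the limit of > 125000 nM in this assay, at which 3 of the 3 values shown sit.

Compound 4, `CCOC(=O)c1cnc(N2CCN(Cc3ccccc3[N+](=O)[O-])CC2)nc1Oc1c(C)cc(-c2ccc(C#N)cc2)cc1C`, differs from compound 2 by 2-nitrophenyl in place of 4-(trifluoromethyl)phenyl on a saturated chain carbon bound to an amine nitrogen in a ring. Within the data shown here, no measured step gives a readable size for a change at this place, so the only guide is that every benzyl variant tested so far sits at the limit. Compound 4 is expected to do the same, at 125000 nM with a range from 60000 nM to 250000 nM. The implied step, a number no higher from compound 2 to compound 4 (the limit leaves the size open), is expected to be none beyond the scatter, most likely reported again as a limit.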

Compound 4, half-maximal cytotoxic concentration: >= 78700 nM
Compound 4 gave a limit, no number; the forecaster's own chance of this, stated with the estimate: 85%; the middle value lies beyond the limit too.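

In this assay compound 4 gives >= 78700 nM, a limit and not a number. Its steps from compound 1, compound 2 and compound 3 therefore cannot be read. The compounds shown leave open the concentration at which any of these four benzyl variants reaches half-maximal cytotoxicity.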